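Moving the naphthyl attachment point on a quinoline hydrazone

The source may hold more compounds than are shown below. What is called first, only, known or untested is meant among the compounds shown, and "the series" means these compounds.

Compound 1 `Cc1ccc2nc(Cl)c(/C=N/n3cc(-c4ccc(Br)cc4)nc3N)cc2c1`: 39300 nM
Compound 2 `Cc1ccc2nc(Cl)c(/C=N/n3cc(-c4cccc5ccccc45)nc3N)cc2c1`: 8300 nM

In a functional assay on DLD-1 cells (Homo sapiens) for cytotoxicity, read by MTT assay, with a stated time of 48 h (a higher number here means a weaker inhibitor, a lower number a stronger inhibitor), compound 1 gives 39300 nM, while compound 2 gives 8300 nM. Going by the values given here, compound 2 therefore has the lower of the two numbers, and the single measured step, a 4.7-fold lower number from compound 1 to compound 2 (0.68 log units; beyond the scatter), places it clearly apart from compound 1 in this assay.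

Compound 3 `Cc1ccc2nc(Cl)c(/C=N/n3cc(-c4ccc5ccccc5c4)nc3N)cc2c1` keeps everything in compound 2 except the point at which the naphthyl group is attached: naphthalen-2-yl in place of naphthalen-1-yl on an aromatic carbon. The two molecules contain the same atoms, joined differently.

Among the compounds with values here, no measured step bears on this change directly. Within the data shown here, the only step available, a 4.7-fold lower number from compound 1 to compound 2 (0.68 log units; beyond the scatter), swapped a bromophenyl group for a naphthyl group, which is a different kind of change from shifting where an unchanged naphthyl group is joined. With nothing to indicate a direction, the expected step of a 1.1-fold higher number from compound 2 to compound 3 (0.04 log units; within the scatter) is none beyond the scatter, with a range wide enough to admit a modest move either way. Compound 3 is thus estimated to give 9000 nM in this assay, within 3000 nM to 30000 nM.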

Compound 3, half-maximal inhibitory concentration: 10200 nM
Beside the measured number, compound 3's estimate is 1.1-fold (0.05 log units) below it; the range from low to high includes it.
By their numbers in this assay, from the lowest: compounds 2 and 3 (each within the scatter of the next); then compound 1.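

In this assay, shifting the attachment point gives a 1.2-fold higher number from compound 2 to compound 3 (0.09 log units; within the scatter), so on this aromatic carbon of the five-membered ring, the naphthalen-1-yl and naphthalen-2-yl groups cannot be told apart. The step away from the bromophenyl compound also holds for the second naphthyl group, with a 3.9-fold lower number from compound 1 to compound 3 (0.59 log units; beyond the scatter), which means that both naphthyl compounds now stand clear of compound 1. Across these three compounds, then, what separates the numbers is having a naphthyl group in place of 4-bromophenyl, not the point at which the naphthyl group is joined, though no supporting evidence explains either observation.

Going by these compounds, all three compounds carry a carbon-only aromatic group or a bromophenyl group at this position, so it remains open how a group containing ring nitrogen, such as pyridin-3-yl, or a phenyl ring bearing a carboxylic acid would behave there. Also open, on these data alone, is whether the two naphthyl compounds would continue to match when another part of the shared core is changed, for instance when the amino group on the five-membered ring is replaced.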